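A Benzyl Group Replaces the Aryl at the Ring Nitrogen

The source may report more compounds than this note shows. Statements on the series, on what has been measured and on what is new or still open speak of the compounds shown alone.

Compound 1 `Cc1cccc(-n2cc(CNC(=O)c3cccc4c3cnn4C(C)C)nn2)c1`: in a functional assay on MCF7 cells (Homo sapiens) for inhibition, read by MTT assay, with a stated time of 72 h (a lower number here means a stronger inhibitor, a higher number a weaker inhibitor), compound 1 gives > 40000 nM, which is a limit of the assay and not a number.
Compound 2 `CC(C)n1ncc2c(C(=O)NCc3cn(-c4ccc(C(F)(F)F)cc4)nn3)cccc21`: in this assay compound 2 gives > 40000 nM, again a limit rather than a measured number.

For the measured compounds named here, compound 2 therefore stands only at a limit, and the one other value shown is a limit as well. The move from compound 1 to compound 2 is a step that the two limits leave unreadable from compound 1 to compound 2, so its size cannot be read, a consequence of the limit of > 40000 nM in this assay, at which 2 of the 2 values shown sit.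

Compound 3 `CC(C)n1ncc2c(C(=O)NCc3cn(Cc4ccccc4)nn3)cccc21` is the next compound and is not yet measured. It differs from compound 2 as follows: benzyl in place of 4-(trifluoromethyl)phenyl on an aromatic nitrogen.

Going by the values given here, no measured step shows what exchanging a substituent on this aromatic nitrogen does, since the only step available is unreadable. The expectation for compound 3 is therefore that it behaves like compound 2, whose result is a limit, and the step of a number no higher from compound 2 to compound 3 (the limit leaves the size open) is estimated to stay within the scatter. Compound 3 is estimated at 40000 nM, between 15000 nM and 120000 nM, most likely reported once more as a limit.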

Compound 3, half-maximal inhibitory concentration: 9170 nM
The estimate for compound 3 lay 4.4-fold (0.64 log units) above the measured number, outside the stated range (below it).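

For the compounds shown here, compound 3 is the first compound here to give a number in this assay rather than a limit, which shows that the group on this aromatic nitrogen can change the result. Benzyl in place of 4-(trifluoromethyl)phenyl gives an at least 4.3-fold lower number from compound 2 to compound 3 (0.63 log units; beyond the scatter), and benzyl in place of 3-methylphenyl gives an at least 4.3-fold lower number from compound 1 to compound 3 (0.63 log units; beyond the scatter). Both steps are minimum sizes, and the true differences cannot be read, because compound 1 and compound 2 give only limits: the limit of > 40000 nM in this assay, at which 2 of the 3 values shown sit.

The compounds shown leave open whether the lower number depends on the benzyl group as a whole or simply on the absence of the substituted phenyl groups, since unsubstituted phenyl does not appear among them. A 4-(trifluoromethyl)benzyl group or a longer chain such as 2-phenylethyl on the same nitrogen would help to separate these possibilities, and would also show whether the number can fall further from that of compound 3, 9170 nM.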